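Selenocyanate linker variation on a shared quinazoline-free core

This account rests on a few compounds, and the source may have more. Where it says the series, first, only, none or still open, it means among the compounds named here.

Measured compounds in a functional assay on RKO cells (Homo sapiens) for inhibition, read by MTT assay, with a stated time of 48 h; a lower number here means a stronger inhibitor, a higher number a weaker inhibitor:
compound 1 `COc1ccc(N(C)c2nc(C)nc3ccccc23)cc1C(=O)NCC[Se]C#N` gives 1170 nM
compound 2 `COc1ccc(N(C)c2nc(C)nc3ccccc23)cc1OCCCCC[Se]C#N` gives 3560 nM
compound 3 `COc1ccc(N(C)c2nc(C)nc3ccccc23)cc1OCCCCCC[Se]C#N` gives 1540 nM

In this assay compound 3 sits second highest of the three numbers; compound 1 lies within the scatter of it, compound 2 beyond it. Compound 4 `COc1ccc(N(C)c2nc(C)nc3ccccc23)cc1OCCC[Se]C#N` is unmeasured and differs from compound 3 by a group of 3 heavy atoms (1 carbon, 1 nitrogen, 1 selenium; no ring) in place of a group of 6 heavy atoms (4 carbon, 1 nitrogen, 1 selenium; no ring), on a saturated chain carbon, three bonds along the chain from an oxygen on an aromatic ring. Within the data shown here, the one measured step that bears on this kind of change is a 2.3-fold lower number from compound 2 to compound 3 (0.36 log units; beyond the scatter), a modest shift; the step of a 1.3-fold higher number from compound 1 to compound 3 (0.12 log units; within the scatter) stays within the scatter and involves a different attachment. Among the measured compounds shown here, only one chain-length comparison exists, so the direction is weakly supported. Compound 4 is expected to show a modest rise, a 1.6-fold higher number from compound 3 to compound 4 (0.21 log units; within the scatter), with an estimate of 2500 nM and a range of 900 nM to 7000 nM.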

Compound 4, half-maximal inhibitory concentration: 799 nM
For compound 4 the middle estimate is 3.1-fold (0.50 log units) above the measured one, outside the stated range (below it).
By their numbers in this assay, from the lowest: compounds 4, 1 and 3 (each within the scatter of the next); then compound 2.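

In this assay, among these compounds, the group of 3 heavy atoms gives a clear drop against the intermediate chain (a 4.5-fold lower number from compound 2 to compound 4 (0.65 log units; beyond the scatter)), so the shorter chain does not bring the rise that the single earlier chain step pointed to. Against the group of 6 heavy atoms the change stays within the scatter (a 1.9-fold lower number from compound 3 to compound 4 (0.28 log units; within the scatter)), leaving compound 2 above both neighbouring chains, with no steady trend across these three. The ether chain of compound 4 also remains within the scatter of the amide-linked compound 1 (a 1.5-fold lower number from compound 1 to compound 4 (0.17 log units; within the scatter)).

No evidence here explains why compound 2 stands apart. On these data alone, whether a longer chain, or a thiocyanate in place of the selenocyanate, would keep these numbers remains open.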